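The source may report more compounds than this note shows. Statements on the series, on what has been measured and on what is new or still open speak of the compounds shown alone.

Within the data shown here, in a functional assay on SK-OV-3 cells (Homo sapiens) for antiproliferative activity, read by MTT assay, with a stated time of 72 h (on this read-out higher numbers stand for weaker inhibition and lower numbers for stronger inhibition), two compounds built on one shared core have numbers so far. Compound 1 `COc1ccc(-c2cccc(NC(=O)CCc3cccc4c3B(O)OC4)c2)cc1` gives 48 nM, while compound 2 `O=C(CCc1cccc2c1B(O)OC2)Nc1cccc(-c2cccc(C(F)(F)F)c2)c1` gives 390 nM, the higher of the two numbers and so the weaker inhibition. Among the measured compounds shown here, the one measured step is an 8.1-fold higher number from compound 1 to compound 2 (0.91 log units; beyond the scatter), which lies beyond the scatter and comes with 3-(trifluoromethyl)phenyl in place of 4-methoxyphenyl on an aromatic carbon. Compound 3 `N#Cc1ccc(-c2cccc(NC(=O)CCc3cccc4c3B(O)OC4)c2)cc1` has not yet been measured. It departs from compound 2 at that same carbon, with 4-cyanophenyl in place of 3-(trifluoromethyl)phenyl on an aromatic carbon. For the measured compounds named here, only the step to compound 2 bears on this change, and it is a single comparison involving a different incoming group, so it offers limited guidance. The 4-cyanophenyl group shares its naming position with the 4-methoxyphenyl group of compound 1, which gives 48 nM, so a partial move back towards that number is expected. The expected change is a 3.0-fold lower number from compound 2 to compound 3 (0.48 log units; beyond the scatter), a modest move towards stronger inhibition. For compound 3 the estimated value is 130 nM, with an expected range from 35 nM to 480 nM.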

Compound 3, half-maximal inhibitory concentration: 340 nM
Compound 3: the middle estimate sits 2.6-fold (0.42 log units) below what was measured; low and high end bracket the measured number.
By their numbers in this assay, from the lowest: compound 1; then compounds 3 and 2 (each within the scatter of the next).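

In this assay, the step of a 1.1-fold lower number from compound 2 to compound 3 (0.06 log units; within the scatter) shows that on this aromatic carbon 4-cyanophenyl and 3-(trifluoromethyl)phenyl cannot be told apart, so a group named as substituted at the 4-position, as in compound 1, does not by that alone bring the number close to that of compound 1. The step of a 7.1-fold higher number from compound 1 to compound 3 (0.85 log units; beyond the scatter), with cyano in place of methoxy, shows that the identity of the group matters at this place even when the numbering in its name stays the same, and it leaves compound 1 alone as the strongest inhibitor of the three, with its steps to both others beyond the scatter. No measurement is at hand that would explain why methoxy and cyano differ here.

Among the compounds shown, no group appears at two places on the ring, so the contribution of the group and that of its location cannot be separated. From the compounds shown here alone, whether the number of compound 1 is particular to methoxy, or would also come with an ethoxy, a hydroxyl or an amine in its place, stays open.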